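The source may hold more compounds than are shown below. What is called first, only, known or untested is meant among the compounds shown, and "the series" means these compounds.

Compound 2 `COc1ccc(-c2cccc(C(=O)N(C)c3ccccn3)c2)cc1S(=O)(=O)Nc1cccc(NCCNC(=O)c2cccc(C)c2)c1` is tested in a functional assay on CHO-RD-HGA16 cells for agonist activity at Orexin/Hypocretin receptor type 1 (Homo sapiens), read by fluorescence and calcium flux, with a stated time of 30 min; on this read-out higher numbers stand for an effect only at larger amounts of compound and lower numbers for an effect already at smaller amounts. In this assay compound 2 reaches only the limit of > 10000 nM, so no number is known for it. Its close relative compound 1 `COc1ccc(-c2cccc(C(=O)NCCN(C)C)c2)cc1S(=O)(=O)Nc1cccc(NCCNC(=O)c2cccc(C)c2)c1` also sits at a limit in this assay, giving > 10000 nM. The step that the two limits leave unreadable from compound 1 to compound 2 cannot be read, because both values sit at the same limit (the limit of > 10000 nM in this assay, at which 2 of the 2 values shown sit). Compound 3 `COc1ccc(-c2cccc(C(=O)N(C)Cc3ccccn3)c2)cc1S(=O)(=O)Nc1cccc(NCCNC(=O)c2cccc(C)c2)c1` differs from compound 2 by one change: (pyridin-2-yl)methyl in place of pyridin-2-yl on an amide-type nitrogen. For the measured compounds named here, the only measured step, from compound 1 to compound 2, says nothing about the size or direction of the effect of this change, since it is unreadable (the limit of > 10000 nM in this assay, at which 2 of the 2 values shown sit). With both measured relatives at the limit, compound 3 is expected to sit near that limit as well. The estimate for compound 3 in this assay is 15000 nM, with a range from 4000 nM to 60000 nM, which means an expected step that the limit leaves unreadable from compound 2 to compound 3.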

Compound 3, half-maximal effective concentration: 235 nM
Beside the measured number, compound 3's estimate is 64-fold (1.81 log units) above it; the whole stated range lies above it.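

In this assay, (pyridin-2-yl)methyl in place of pyridin-2-yl on the amide-type nitrogen gives an at least 42-fold lower number from compound 2 to compound 3 (1.62 log units; beyond the scatter), so this position can carry a compound from no readable effect to a measured number. Set against the dimethylaminoethyl amide, the methyl((pyridin-2-yl)methyl)amino group on the carbonyl carbon gives an at least 42-fold lower number from compound 1 to compound 3 (1.62 log units; beyond the scatter), so two different starting points lead to the same large gain. Both steps are minimum sizes rather than exact ones, because neither starting compound has a number: the limit of > 10000 nM in this assay, at which 2 of the 3 values shown sit.

The compounds shown do not tell whether a longer chain, such as 2-(pyridin-2-yl)ethyl, would lower the number further. They also leave open whether the ring nitrogen matters, a question that a benzyl group on the same amide nitrogen would address.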